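A longer acid chain on a shared thioether core

This account rests on a few compounds, and the source may have more. Where it says the series, first, only, none or still open, it means among the compounds named here.

Measured compounds:
Compound 1 `CCCCCCCSc1cc(-c2ccccc2)c(-c2ccccc2)nn1`: 76000 nM
Compound 2 `O=C(O)CCCCCCSc1cc(-c2ccccc2)c(-c2ccccc2)nn1`: > 300000 nM (a limit, not a number)

In an assay on microsomes from liver for inhibition of sterol O-acyltransferase 1 (Rattus norvegicus) (on this read-out lower numbers stand for stronger inhibition and higher numbers for weaker inhibition), compound 1 gives 76000 nM. For compound 2 this assay reports only a limit of > 300000 nM, so no number is known for it. The step of an at least 3.9-fold higher number from compound 1 to compound 2 (0.59 log units; beyond the scatter) places compound 2 at the weak end of the two values shown, sitting at the limit of > 300000 nM in this assay, at which 1 of the 2 values shown sits.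

Compound 3 `O=C(O)CCCCCCCCSc1cc(-c2ccccc2)c(-c2ccccc2)nn1` is not yet measured. It differs from compound 2 by 2-carboxyethyl in place of carboxy on a saturated chain carbon, six bonds along the chain from a sulfur. For the measured compounds named here, no measured step covers a change of this kind; the only measured step, an at least 3.9-fold higher number from compound 1 to compound 2 (0.59 log units; beyond the scatter), concerns the arrival of the carboxy group, which compound 3 keeps. With the acid retained, compound 3 is expected to remain near the limit, and no step beyond the scatter is expected in this assay; a number no higher from compound 2 to compound 3 (the limit leaves the size open) is the estimated step. Compound 3 is therefore estimated at 300000 nM, within 100000 nM to 1000000 nM in this assay.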

Compound 3, half-maximal inhibitory concentration: > 300000 nM
Compound 3: no number, only a limit; the forecaster's own chance of this, stated with the estimate: 70%; the middle value sits exactly at the limit.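

In this assay compound 3 also gives only a limit, > 300000 nM, and not a number. Carboxymethyl in place of hydrogen on a saturated chain carbon, seven bonds along the chain from a sulfur, gives an at least 3.9-fold higher number from compound 1 to compound 3 (0.59 log units; beyond the scatter), so the weak result seen with the shorter acid also holds for this longer acid chain. The step between the two acids cannot be read, but 2-carboxyethyl in place of carboxy brings no number into view: the limit of > 300000 nM in this assay, at which 2 of the 3 values shown sit.

On these data alone, how far the two acids lie past this limit, and whether they differ from each other, remains open. As far as these compounds go, it is also open whether a methyl ester, a primary amide or an amine at the end of the chain would give a readable value in this assay.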